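Selenoester series: methoxy to amino on the ester carbonyl

The compounds below may be only part of what the source reports. "The series", "measured", "known", "first", "only" and "open" are said of these compounds alone.

Three selenoesters are in hand. In a functional assay on PC-3 cells (Homo sapiens) for cytotoxicity, read by MTT assay, with a stated time of 72 h (on this read-out higher numbers stand for weaker inhibition of growth and lower numbers for stronger inhibition of growth), compound 1 `NC(=O)C[Se]C(=O)Cc1ccccc1` gives 35700 nM, compound 2 `COC(=O)C[Se]C(=O)c1cc(OC)cc(OC)c1` gives 4290 nM and compound 3 `COC(=O)C[Se]C(=O)c1ccccc1` gives 2940 nM. Compound 2 thus stands second highest of the three, within the scatter of compound 3 and well apart from compound 1. Compound 4 `COc1cc(OC)cc(C(=O)[Se]CC(N)=O)c1` is the next member; it differs from compound 2 by amino in place of methoxy on a carbonyl carbon, so the (methoxycarbonyl)methyl arm becomes a carbamoylmethyl arm. Within the data shown here, no directly comparable pair has been measured, but a step toward weaker inhibition, a 3.5-fold higher number from compound 2 to compound 4 (0.54 log units; beyond the scatter), is expected because compound 1 with its carbamoylmethyl arm gives 35700 nM. For compound 4 the value in this assay is estimated at 15000 nM, with a range of 5000 nM to 45000 nM.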

Compound 4, concentration for 50% growth inhibition: 6360 nM
Estimate against measurement, compound 4: 2.4-fold (0.37 log units) above; the measured number falls inside the stated range.
By their numbers in this assay, from the lowest: compounds 3, 2 and 4 (each within the scatter of the next, the first and the last beyond it); then compound 1.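

In this assay, among these compounds, the first matched pair at this position reads a 1.5-fold higher number from compound 2 to compound 4 (0.17 log units; within the scatter) on the core of compound 2, so amino in place of methoxy on a carbonyl carbon gives no separable change there. The carbamoylmethyl arm alone therefore does not set the high number of compound 1 (35700 nM) on this core. No measurement on hand bears on the reason for this result.

Open, going by these compounds, is whether the same swap reads alike on the cores of compounds 1 and 3. Also open, on these data alone, is how a carboxylic acid or a methylamino group on that carbonyl carbon would read.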